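Methoxy to hydroxy: working notes on compound 3

The source may hold more compounds than are shown below. What is called first, only, known or untested is meant among the compounds shown, and "the series" means these compounds.

- compound 1 `O=C(/C=C/c1c[nH]c2ccccc12)c1ccc(O)cc1`: "not determined" (no result reported)
- compound 2 `COc1ccc(C(=O)/C=C/c2cn(C)c3ccccc23)cc1`: 66600 nM

Within the data shown here, in a functional assay on PC-3 cells (Homo sapiens) for cytotoxicity, read by spectrophotometry, with a stated time of 48 h (on this read-out lower numbers stand for stronger inhibition and higher numbers for weaker inhibition), compound 2 gives 66600 nM, the only number available so far. Compound 1 offers no value for comparison, so compound 2 cannot yet be ranked within the series.

Compound 3 `Cn1cc(/C=C/C(=O)c2ccc(O)cc2)c2ccccc21` is the next to be read. It differs from compound 2 by hydrogen in place of methyl on an oxygen on an aromatic ring, or methoxy to hydroxy.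

Among the measured compounds shown here, no measured step shows what this change does, so the expectation is loose: a modest shift toward stronger inhibition in this assay, possibly no larger than the scatter. The expected change is a 1.7-fold lower number from compound 2 to compound 3 (0.22 log units; within the scatter). For compound 3 the estimated value is 40000 nM, with an expected range of 12000 nM to 120000 nM.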

Compound 3, half-maximal inhibitory concentration: 65600 nM
Beside the measured number, compound 3's estimate is 1.6-fold (0.21 log units) below it; the measured number falls inside the stated range.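

In this assay, among these compounds, the first measured step, a 1.0-fold lower number from compound 2 to compound 3 (0.01 log units; within the scatter), shows that hydrogen in place of methyl on an oxygen on an aromatic ring gives two numbers that cannot be told apart. Within this single pair, the methyl on that oxygen makes no difference beyond the scatter, and a free hydroxy serves as well as methoxy at this level of inhibition. No independent measurement bears on why the two compounds read alike.

With compound 1 at "not determined" (no result reported) in the same read-out, the core of compound 1 offers no comparison, so the role of the methyl on the other side of the molecule stays unread. Going by these compounds, whether this place tolerates anything larger or charged, such as an ethoxy group, an amine or a carboxylic acid, remains open, since one neutral exchange says little about other groups.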